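The compounds below may be only part of what the source reports. "The series", "measured", "known", "first", "only" and "open" are said of these compounds alone.

Compound 1 `Cc1[nH]cnc1[C@@H]1[C@@H](c2cc(Cl)cc(Cl)c2)C1(C)C` gives 950 nM in a functional assay on AP1 cells for inhibition of sodium/hydrogen exchanger 1 (Homo sapiens); a higher number here means a weaker inhibitor, a lower number a stronger inhibitor.
Compound 3 `CC1(C)[C@H](c2cc(Cl)cc(Cl)c2)[C@H]1c1c[nH]cn1` gives 4000 nM in this assay.
Compound 2 `CC1(C)[C@H](c2cnc(N)s2)[C@H]1c1cccc2c1CCO2` reaches only the limit > 30000 nM in this assay.

Of these three, compound 2 alone has no number: its result is a limit of the assay, not a measured value, and it stands at the limit of > 30000 nM in this assay, at which 1 of the 3 values shown sits. Compound 4 `CC1(C)[C@H](c2nc(N)no2)[C@H]1c1cccc2c1CCO2` differs from compound 2 in one place: 3-amino-1,2,4-oxadiazol-5-yl in place of 2-amino-1,3-thiazol-5-yl on a saturated ring carbon. Going by the values given here, the only measured step, a 4.2-fold higher number from compound 1 to compound 3 (0.62 log units; beyond the scatter), concerns a methyl removed from an aromatic ring on a different core and does not touch an exchange of one amino-bearing five-membered ring for another, so no measured step bears directly on this change. Among the compounds with values here, the starting point is therefore the sole guide. For compound 4 the expectation is weak inhibition much like compound 2, with the step from compound 2 to compound 4 estimated at a step that the limit leaves unreadable from compound 2 to compound 4. Compound 4 is thus estimated at 40000 nM, within a range from 10000 nM to 150000 nM, and it may well again be reported only as a limit.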

Compound 4, half-maximal inhibitory concentration: 30000 nM
Compound 4: the middle estimate sits 1.3-fold (0.12 log units) above what was measured; measured number inside the range.
By their numbers in this assay, from the lowest: compound 1; then compound 3; then compound 4.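

In this assay compound 4 gives an actual reading of 30000 nM and so a group on this saturated ring carbon now has a measured number on this core. The size of the exchange of 2-amino-1,3-thiazol-5-yl for 3-amino-1,2,4-oxadiazol-5-yl still cannot be read, because compound 2 stands only at a limit: the limit of > 30000 nM in this assay, at which 1 of the 4 values shown sits. All that can be said is that the exchange gives a number no higher from compound 2 to compound 4 (the limit leaves the size open) and the reading stays at the weak end.

On these data alone, what stays open is how this core would read with a guanidine on this saturated ring carbon, or with a hydroxyl or methyl in place of the amino group on the five-membered ring. Also open, as far as these compounds go, is whether a 4.2-fold higher number from compound 1 to compound 3 (0.62 log units; beyond the scatter) has any counterpart on the core of compound 4.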